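Chloro to methyl on the chlorophenoxy end of compound 1

This account rests on a few compounds, and the source may have more. Where it says the series, first, only, none or still open, it means among the compounds named here.

Compound 1 `O=C(CSc1nc2ccccc2s1)N/N=C/c1ccc(Oc2ccc(Cl)cc2)cc1` stands highest of the three numbers in a physicochemical assay for lipophilicity, in phosphate buffer, measured as octanol-water partition, with a stated time of 24 h (on this read-out higher numbers stand for higher lipophilicity and lower numbers for lower lipophilicity), giving 5.6. The nearest number belongs to compound 2 `O=[N+]([O-])c1ccc(Oc2ccc(/C=N/Nc3nc4ccccc4s3)cc2)cc1`, which in this assay gives 5.1, a gap beyond the scatter. The furthest belongs to compound 3 `O=C(CSc1nc2ccccc2s1)N/N=C1\C(=O)Nc2ccccc21`, which in this assay gives 3.2, a gap well beyond the scatter.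

Compound 4 `Cc1ccc(Oc2ccc(/C=N/NC(=O)CSc3nc4ccccc4s3)cc2)cc1` differs from compound 1 in one place: methyl in place of chloro on an aromatic carbon. For the measured compounds named here, no pair of measured compounds shows this exchange, so the step has no direct precedent. An exchange of one heavy atom for one heavy atom, with no change in ring count, donors, acceptors or charge, is expected to move the number only a little, if at all. The expected step from compound 1 to compound 4 is a number 0.10 log units lower from compound 1 to compound 4 (within the scatter), within the scatter. Compound 4 is therefore expected to give 5.5, with a range from 5.1 to 5.9.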

Compound 4, partition coefficient: 5.7
Estimate against measurement, compound 4: 0.20 log units below; the measured number falls inside the stated range.
By their numbers in this assay, from the lowest: compound 3; then compound 2; then compounds 1 and 4 (each within the scatter of the next).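

In this assay, for the compounds shown here, methyl in place of chloro on this aromatic carbon gives a number 0.10 log units higher from compound 1 to compound 4 (within the scatter) as the first step read at a single place. Chloro and methyl cannot be told apart at this position on this read-out, so the high number of compound 1 does not require the chloro. Nothing measured gives a reason for this step.

On these data alone, an amine, a carboxylic acid or a longer chain at this position remains open. So does whether methyl for chloro gives a similar step on another core.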